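The source may report more compounds than this note shows. Statements on the series, on what has been measured and on what is new or still open speak of the compounds shown alone.

Compounds measured so far:

Compound 1, `COc1cc(/C=C/C(=O)c2cccc(-n3cc(-c4ccc(Cl)cc4)[nH]c3=O)c2)cc(OC)c1OC`, in a functional assay on A498 cells (Homo sapiens) for inhibition (on this read-out lower numbers stand for stronger inhibition of growth and higher numbers for weaker inhibition of growth), gives 30200 nM.
Compound 2, `COc1cc(/C=C/C(=O)c2cccc(-n3cc(-c4ccccc4)[nH]c3=O)c2)cc(OC)c1OC`, in this assay gives 2650 nM.
Compound 3, `COc1ccc(-c2cn(-c3cccc(C(=O)/C=C/c4cc(OC)c(OC)c(OC)c4)c3)c(=O)[nH]2)cc1`, in this assay gives 4210 nM.

Compound 3 holds the second highest number of the three. Its nearest neighbour is compound 2, with the two values lying within the scatter of each other, while compound 1 stands furthest away, and that gap is beyond the scatter.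

Compound 4, `COc1cc(/C=C/C(=O)c2cccc(-n3cc(-c4cc(OC)c(OC)c(OC)c4)[nH]c3=O)c2)cc(OC)c1OC`, differs from compound 3 in one place: 3,4,5-trimethoxyphenyl in place of 4-methoxyphenyl on an aromatic carbon. Within the data shown here, two measured steps bear on this. The step of a 1.6-fold higher number from compound 2 to compound 3 (0.20 log units; within the scatter) shows that putting a methoxy onto this aromatic carbon left the number essentially where it was. The step of a 7.2-fold lower number from compound 1 to compound 3 (0.86 log units; beyond the scatter) shows a modest drop when methoxy replaced chloro there. Neither step involves adding a second and third methoxy, so the data give no direct guide beyond the observation that a methoxy on this aryl has so far cost nothing. Compound 4 is therefore expected to stay close to compound 3, with the estimated step of a 1.1-fold lower number from compound 3 to compound 4 (0.02 log units; within the scatter) lying within the scatter. The estimate for compound 4 in this assay is 4000 nM, ranging from 1300 nM to 12000 nM.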

Compound 4, concentration for 50% growth inhibition: 20300 nM
Compound 4: the middle estimate sits 5.1-fold (0.71 log units) below what was measured, outside the stated range (above it).
By their numbers in this assay, from the lowest: compounds 2 and 3 (each within the scatter of the next); then compounds 4 and 1 (each within the scatter of the next).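

At this aromatic carbon of the five-membered ring, 3,4,5-trimethoxyphenyl does not read like 4-methoxyphenyl in this assay: the change gives a 4.8-fold higher number from compound 3 to compound 4 (0.68 log units; beyond the scatter) and, set against phenyl, a 7.7-fold higher number from compound 2 to compound 4 (0.88 log units; beyond the scatter). The earlier result, where a single methoxy left the number where it was, therefore does not carry over to the trimethoxy group, and the aryl position proves sensitive to more than the chloro group alone; the step from the 4-chlorophenyl compound (a 1.5-fold lower number from compound 1 to compound 4 (0.17 log units; within the scatter)) puts these two compounds level, apart from compounds 2 and 3. Nothing available here gives a reason for this rise.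

The compounds shown leave open whether it takes all three methoxy groups to raise the number or whether fewer would do. They also leave open how a hydroxyl group or an amine on this aryl ring would read.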